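The compounds below may be only part of what the source reports. "The series", "measured", "known", "first", "only" and "open" are said of these compounds alone.

Measured in a toxicity assay on cells (Fibroblast, Homo sapiens) for cytotoxicity; on this read-out higher numbers stand for weaker inhibition and lower numbers for stronger inhibition:
- Compound 1 `CC(/C=C/C1=CCCCC1(C)C)=C\C=C\C(C)=C\COC(=O)c1ccccc1O`: 150000 nM
- Compound 2 `COc1cc(NC(C)=O)cc(C(=O)OC/C=C(C)/C=C/C=C(C)/C=C/C2=CCCCC2(C)C)c1O`: < 10000 nM (a limit)

Compound 2 has no exact number in this assay. Its reading of < 10000 nM is a limit of the assay.

Compound 3 `COc1cccc(C(=O)OC/C=C(C)/C=C/C=C(C)/C=C/C2=CCCCC2(C)C)c1O` differs from compound 2 by hydrogen in place of acetamido on an aromatic carbon, para to a hydroxy group: hydrogen in place of acetamido on an aromatic carbon. Going by the values given here, no measured pair shows what this change does, so the expectation is a loose one. A moderate step towards weaker inhibition is expected in this assay, though a result within the scatter would be no surprise. Among the compounds with values here, this expectation leans towards the only exact number available, which is compound 1 at 150000 nM. The expected size of the change is an at least 2.0-fold higher number from compound 2 to compound 3 (0.30 log units; that floor lies within the scatter). Compound 3 is estimated at 20000 nM, with an expected range of 5000 nM to 100000 nM.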

Compound 3, half-maximal inhibitory concentration: 27000 nM
Compound 3: middle estimate off by 1.4-fold (0.13 log units), on the low side, within the range that was stated.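

In this assay, compound 2 stands only as a limit, < 10000 nM. Hydrogen in place of acetamido, para to a hydroxy group, gives an at least 2.7-fold higher number from compound 2 to compound 3 (0.43 log units; beyond the scatter), so at this position acetamido goes with stronger inhibition, and this step can be given only as a bound because one end of it rests on a limit: the limit of < 10000 nM in this assay, at which 1 of the 3 values shown sits. The exact reading for compound 3 also gives the first exact step in the series, for methoxy in place of hydrogen on an aromatic carbon, with a 5.6-fold lower number from compound 1 to compound 3 (0.74 log units; beyond the scatter).

As far as these compounds go, how far the acetamido step really reaches stays open until compound 2 has an exact number. From the compounds shown here alone, it also remains open whether this effect is particular to acetamido, or whether an amine, a carboxylic acid or a longer acyl chain at the same position would read alike.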